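Cytotoxicity notes: bromophenyl amide variant of compound 3

This account rests on a few compounds, and the source may have more. Where it says the series, first, only, none or still open, it means among the compounds named here.

Compound 3 `CN(C)c1cc2[nH]c(C3CCCCC3)nc2cc1NC(=O)c1ccc(OC(F)F)cc1` carries a dimethylamino group and a 4-(difluoromethoxy)phenyl amide on the shared core. In an ADME assay on Vero cells (Chlorocebus sabaeus) for cytotoxicity, read by resazurin assay, with a stated time of 3 days (a higher number here means a weaker inhibitor, a lower number a stronger inhibitor), compound 3 gives > 100 ug/mL, which is a limit of the assay and not a number. Compound 1 `CN(C)c1cc2[nH]c(C3CCCCC3)nc2cc1NC(=O)c1ccc(Br)cc1` has bromo in place of difluoromethoxy. In this assay compound 1 gives > 100 ug/mL, again a limit. Compound 2 `CCN(CC)c1cc2[nH]c(C3CCCCC3)nc2cc1NC(=O)c1ccc(OC(F)F)cc1` has diethylamino in place of dimethylamino. In this assay compound 2 gives > 100 ug/mL, also a limit. The step from compound 1 to compound 3 is a step that the two limits leave unreadable from compound 1 to compound 3, and that from compound 2 to compound 3 is a step that the two limits leave unreadable from compound 2 to compound 3; all three values sit at the limit of > 100 ug/mL in this assay, at which 3 of the 3 values shown sit, so compound 3 stands level with the others there.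

Compound 4 `CN(C)c1cc2[nH]c(C3CCCCC3)nc2cc1NC(=O)c1cccc(Br)c1` is the unmeasured member: 3-bromophenyl in place of 4-(difluoromethoxy)phenyl on a carbonyl carbon. Both measured steps are unreadable, so no direction can be taken from them. The expected step in this assay is a number no higher from compound 3 to compound 4 (the limit leaves the size open), within scatter. Compound 4 is therefore expected to give 100 ug/mL, with a range from 50 ug/mL to 200 ug/mL, most likely reported again as a limit.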

Compound 4, half-maximal inhibitory concentration: > 100 ug/mL
Compound 4 was reported as a limit; the forecaster's own chance of this, stated with the estimate: 85%; the middle value lies on the limit itself.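

In this assay compound 4 gives > 100 ug/mL, which is a limit, so the steps to it from compound 1 and compound 3 cannot be read: the limit of > 100 ug/mL in this assay, at which 4 of the 4 values shown sit.

The compounds shown leave open whether any change on the shared core alters cytotoxicity, and at what concentration any of them reaches half-maximal inhibition.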